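The source may report more compounds than this note shows. Statements on the series, on what has been measured and on what is new or still open speak of the compounds shown alone.

For the measured compounds named here, in a functional assay on 786-0 cells (Homo sapiens) for antiproliferative activity, read by sulforhodamine B assay, with a stated time of 48 h (on this read-out higher numbers stand for weaker inhibition of growth and lower numbers for stronger inhibition of growth), compound 1 `CCCCCCCCCCCCCCCCCC(=O)N1CCOCC1` gives 41.1 ug/mL, the second highest of the three numbers so far. Compound 3 `CCCCC/C=C\C/C=C\CCCCCCCC(=O)N1CCCCC1` gives 58.4 ug/mL, which is within the scatter of compound 1. Compound 2 `CCCCCCCC/C=C\CCCCCCCC(=O)N1CCCC1` gives 5.2 ug/mL, lower than compound 1 by a gap beyond the scatter. The three numbers therefore form one close pair and one clearly separate value.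

The next compound is compound 4 `CCCCCCCCCCCCCCCC(=O)N1CCOCC1`. Its change from compound 1 is hydrogen in place of ethyl on a saturated chain carbon, ten or more bonds along the chain from a carbonyl carbon.

Going by the values given here, no two measured compounds differ in one place only, so nothing yet isolates this change. In this assay, the expectation is for no step beyond the scatter, with at most a slight drift towards a lower number. The estimated step, a 1.4-fold lower number from compound 1 to compound 4 (0.14 log units; within the scatter), stays within the scatter. The expected range extends further downward than usual, since compound 2 at 5.2 ug/mL shows that much lower numbers occur in this small set. For compound 4 the estimated value is 30 ug/mL, with an expected range of 12 ug/mL to 70 ug/mL.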

Compound 4, concentration for 50% growth inhibition: 33.1 ug/mL
Estimate against measurement, compound 4: 1.1-fold (0.04 log units) below; the range from low to high includes it.
By their numbers in this assay, from the lowest: compound 2; then compounds 4, 1 and 3 (each within the scatter of the next).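

In this assay, for the compounds shown here, the pair of compound 1 and compound 4 gives the first step that isolates a single change: a 1.2-fold lower number from compound 1 to compound 4 (0.09 log units; within the scatter). Hydrogen in place of ethyl on a saturated chain carbon therefore leaves this read-out within the scatter for this pair, a reading that the earlier compounds, which differ from one another in more than one place, could not give. No measured evidence bears on this result.

Still open, on these data alone, is whether the double bonds in the chain or the ring on the amide carbonyl account for the separate value of compound 2, as compound 2 and compound 3 each differ from compound 1 in more than one place. Also open, as far as these compounds go, is how a hydroxyl group or a carboxylic acid at this chain carbon, or a chain longer than that of compound 1, would read in this assay, and whether the same step holds with the other amides.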